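The compounds below may be only part of what the source reports. "The series", "measured", "known", "first", "only" and "open" are said of these compounds alone.

In a functional assay on HT-29 cells (Homo sapiens) for antiproliferative activity, read by sulforhodamine B assay, with a stated time of 72 h (a lower number here means a stronger inhibitor, a higher number a weaker inhibitor), compound 1 `CCCCCCCCc1ccc(CCC(CO)(CO)NC(C)=O)c2ccccc12` gives 36500 nM. Compound 2 `COc1ccc(CCC(CO)(CO)NC(C)=O)c2ccccc12` stands at > 80000 nM, which is a limit of the assay and not a number, so only a bound on its position is known.

Next in the series is compound 3 `CCCCCCCOc1ccc(CCC(CO)(CO)NC(C)=O)c2ccccc12`, which differs from compound 2 by hexyl in place of hydrogen on a saturated chain carbon bound to an oxygen on an aromatic ring, or methoxy to heptyloxy when the bond is cut one further out.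

Among the compounds with values here, only one measured step bears on this change: methoxy in place of octyl on an aromatic carbon, an at least 2.1-fold higher number from compound 1 to compound 2 (0.34 log units; beyond the scatter). That step is at least modest, and its true size is hidden by the limit. Within the data shown here, compound 3 regains a long chain, though through an oxygen, so the step from the methoxy compound should run the opposite way to the one from compound 1, towards a lower number in this assay, and be of similar modest size. The expected change is an at least 2.6-fold lower number from compound 2 to compound 3 (0.42 log units; beyond the scatter). For compound 3 the estimated value is 30000 nM, with an expected range of 12000 nM to 75000 nM.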

Compound 3, half-maximal inhibitory concentration: 17600 nM
The estimate for compound 3 lay 1.7-fold (0.23 log units) above the measured number; low and high end bracket the measured number.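

In this assay, the change from methoxy to heptyloxy gives an at least 4.5-fold lower number from compound 2 to compound 3 (0.65 log units; beyond the scatter) and shows that this position can take a long chain joined through oxygen, with a number that lies inside the range of the assay. The size of that step is only a bound, as compound 2 stands at a limit of the assay and not at a number: the limit of > 80000 nM in this assay, at which 1 of the 3 values shown sits. The comparison between the two long chains rests on numbers at both ends, and going from the one long chain to the other gives a 2.1-fold lower number from compound 1 to compound 3 (0.32 log units; beyond the scatter) so that the chain joined through oxygen reads modestly lower than the chain joined directly to the aromatic carbon.

With only methoxy and heptyloxy in the ether set, the compounds shown leave open how the number moves with chain length, including at intermediate chains such as butoxy and at a longer chain such as decyloxy. They also leave open whether a chain ending in an amine or a carboxylic acid would hold or lose the lower number seen for compound 3.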